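Swapping an Acid-Bearing Ring for a Fused Nitrogen Ring

A few compounds are considered here, and "the series" means these few. Any claim that something is new, unique, unknown or untested is made for them only; others in the source may bear on it.

Of the compounds shown here, three sharing one core have been tested in a functional assay on JAR cells (Homo sapiens) for inhibition, read by MTT assay, with a stated time of 72 h, tested at 10 uM; a higher number here means more inhibition at the concentration tested (going by the name of the read-out), a lower number less inhibition. Compound 1 `CCOC(=O)C1=C(Nc2ccccc2)S/C(=C\c2ccc(C(=O)O)cc2)C1=O` gives 16.8%, the lowest of the three numbers. Compound 2 `CCOC(=O)C1=C(Nc2cccc(F)c2)S/C(=C\c2ccc[nH]2)C1=O` gives 45.4%, a reading well beyond the usual scatter above compound 1, and compound 3 `CCOC(=O)C1=C(Nc2ccccc2)S/C(=C\c2ccc(C(=O)OCC)[nH]2)C1=O` gives 60.1%, the highest of the three, again beyond the scatter relative to compound 1. Compound 2 and compound 3 differ from compound 1 in more than one place, so no single change can be tied to those gaps; what their numbers show is simply that compounds bearing a five-membered aromatic ring with one hetero atom at the double-bonded chain carbon read higher than compound 1.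

The unmeasured compound 4 `CCOC(=O)C1=C(Nc2ccccc2)S/C(=C\c2cc3ncccc3[nH]2)C1=O` differs from compound 1 in only one place: a group of 9 heavy atoms (7 carbon, 2 nitrogen; one five-membered aromatic ring with 1 hetero atom, one six-membered aromatic ring with 1 hetero atom) in place of a group of 9 heavy atoms (7 carbon, 2 oxygen; one six-membered aromatic ring of carbon only), on a double-bonded chain carbon bound to a double-bonded ring carbon The group that enters also carries a five-membered aromatic ring with one hetero atom, as in compound 2 and compound 3. Among the measured compounds shown here, on that basis an upward step beyond the scatter is expected in this assay, though its size is uncertain since no single-change step exists among the measured compounds. Compound 4 is expected to give 40%, within a range from 20% to 65%, an estimated step of a number 23.2 percentage points higher from compound 1 to compound 4 (beyond the scatter) from compound 1.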

Compound 4, a percentage reported as inhibition, at one concentration (the size of the read-out at that concentration, not a potency): 74.8%
Estimate against measurement, compound 4: 34.8 percentage points below, and the stated range ends below it.
By their numbers in this assay, from the lowest: compound 1; then compound 2; then compound 3; then compound 4.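

In this assay the swap of the 4-carboxyphenyl group for the group carrying a five-membered and a six-membered aromatic ring, each with 1 hetero atom, gives a number 58 percentage points higher from compound 1 to compound 4 (beyond the scatter) on a double-bonded chain carbon bound to a double-bonded ring carbon. Among the compounds shown here, this is the first comparison in which nothing else in the molecule changes, so the gap can be tied to this one place, and it shows that the reading responds strongly to what sits there. The two groups match in heavy atoms, hydrogen-bond donors and hydrogen-bond acceptors, so those counts do not separate them, and no measurement at hand explains the step.

This single swap removes the carboxylic acid and replaces the carbon-only ring with nitrogen-containing rings at once, so the compounds shown cannot say which of these changes carries the step. A plain phenyl group at this place, or an ethyl ester in place of the carboxylic acid on the same ring, would help to pull those two changes apart.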